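Replacing the benzyl substituent on a nucleoside-type transporter inhibitor

The compounds below may be only part of what the source reports. "The series", "measured", "known", "first", "only" and "open" are said of these compounds alone.

Compound 3 `O=[N+]([O-])c1ccc(CNc2ncnc3c2ncn3[C@@H]2O[C@H](CO)[C@@H](O)[C@H]2O)c(Cl)c1` holds the second highest of the three numbers in an assay on isolated protein for binding affinity to Equilibrative nucleoside transporter 1 (Homo sapiens); on this read-out lower numbers stand for stronger inhibition and higher numbers for weaker inhibition: compound 3 gives 347 nM. Its nearest neighbour, compound 2 `OC[C@H]1O[C@@H](n2cnc3c(CSc4ccc(Br)cc4)ncnc32)[C@H](O)[C@@H]1O`, gives 178 nM, a gap that lies within the usual scatter, so the two cannot be ranked. Compound 1 `Nc1nc(SCCc2ccccc2)c2ncn([C@@H]3O[C@H](CO)[C@@H](O)[C@H]3O)c2n1` gives 16200 nM, a far higher number that lies well beyond the scatter. Compound 4 `COc1cccc(CNc2ncnc3c2ncn3[C@@H]2O[C@H](CO)[C@@H](O)[C@H]2O)c1` has not been measured; it differs from compound 3 by 3-methoxyphenyl in place of 2-chloro-4-nitrophenyl on a saturated chain carbon bound to a nitrogen on an aromatic ring. Among the compounds with values here, no measured pair shows this particular change, so the expected step from compound 3 to compound 4 is a 4.3-fold higher number from compound 3 to compound 4 (0.64 log units; beyond the scatter), toward a higher number, judged a moderate move beyond the scatter. The estimate for compound 4 is 1500 nM, with a range from 400 nM to 6000 nM.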

Compound 4, half-maximal inhibitory concentration: 115000 nM
For compound 4 the middle estimate is 77-fold (1.88 log units) below the measured one; measured number above the stated range.
By their numbers in this assay, from the lowest: compounds 2 and 3 (each within the scatter of the next); then compound 1; then compound 4.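

In this assay, the group on a saturated chain carbon bound to a nitrogen on an aromatic ring matters greatly: 3-methoxyphenyl in place of 2-chloro-4-nitrophenyl gives a 330-fold higher number from compound 3 to compound 4 (2.52 log units; beyond the scatter) with the rest of the compound unchanged. Within the data shown here, compounds 1 and 2 differ from compound 3 in more than one place, so only this pair isolates that group. Nothing available here explains the size of this step.

From the compounds shown here alone, the chlorine and nitro groups leave together, so their separate contributions remain unknown, as does that of the methoxy group. Going by these compounds, how an unsubstituted phenyl or a phenyl bearing a carboxylic acid would compare also remains open.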